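Tolyl in place of methoxyphenyl on the triazole arm

A few compounds are considered here, and "the series" means these few. Any claim that something is new, unique, unknown or untested is made for them only; others in the source may bear on it.

Compound 1 `C=C1C[C@]23C[C@@]1(O)CC[C@H]2c1ccc(OS(=O)(=O)c2ccc(C)cc2)c(C)c1[C@@H]3Cn1cc(-c2ccc(C)cc2)nn1` is one of two measured members of the series. In a functional assay on SMMC-7721 cells (Homo sapiens) for cytotoxicity, read by MTT assay, with a stated time of 4 days (on this read-out lower numbers stand for stronger inhibition and higher numbers for weaker inhibition), compound 1 gives > 20000 nM, a limit of the assay rather than a number. Compound 2 `C=C1C[C@]23C[C@@]1(O)CC[C@H]2c1ccc(O)c(C)c1[C@@H]3Cn1cc(-c2ccc(OC)cc2)nn1` also reaches only a limit: in this assay compound 2 gives > 20000 nM. Both measured values sit at the limit of > 20000 nM in this assay, at which 2 of the 2 values shown sit, so compound 2 stands level with compound 1 on the numbers shown. Compound 3 `C=C1C[C@]23C[C@@]1(O)CC[C@H]2c1ccc(O)c(C)c1[C@@H]3Cn1cc(-c2ccc(C)cc2)nn1` carries methyl in place of methoxy on an aromatic carbon, which cut one bond further out reads 4-methoxyphenyl to 4-methylphenyl. Going by the values given here, no measured step covers this change; the expected step from compound 2 to compound 3 in this assay is a step that the limit leaves unreadable from compound 2 to compound 3, none beyond the scatter. Compound 3 is accordingly estimated at 25000 nM, between 8000 nM and 80000 nM, most probably again reported only as a limit.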

Compound 3, half-maximal inhibitory concentration: > 20000 nM
Compound 3: no number, only a limit (the forecaster's own chance of this, stated with the estimate: 80%); the middle value does not contradict the limit.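

In this assay compound 3 gives > 20000 nM, a limit and not a number. Going by these compounds alone, with compound 1 and compound 2 also at limits, no step to compound 3 can be read. The compounds shown leave open which change, if any, would give a measurable value.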